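Ethyl in place of methoxy: compound 3 to compound 4

The source may report more compounds than this note shows. Statements on the series, on what has been measured and on what is new or still open speak of the compounds shown alone.

Measured so far in an assay on IMR-32 cells for displacement of a labelled ligand from corticotropin-releasing factor receptor 1 (Homo sapiens), read by scintillation counting, with a stated time of 2 h; a higher number here means a weaker inhibitor, a lower number a stronger inhibitor:
compound 1, `CCc1nc(-c2ccc(OC(F)(F)F)cc2OC)c(CC)nc1NC(CC)CC`, gives 7.2 nM
compound 2, `CCc1nc(-c2ccc(OC(F)(F)F)cc2OC)c(OC)nc1NC(CC)CC`, gives 6.1 nM
compound 3, `CCC(CC)Nc1nc(OC)c(-c2ccc(Cl)cc2Cl)nc1OC`, gives 8.4 nM

Compounds 1 and 2 share one core and differ in one place: ethyl in place of methoxy on an aromatic carbon. This step gives a 1.2-fold higher number from compound 2 to compound 1 (0.07 log units; within the scatter), so compound 1 and compound 2 cannot be told apart in this assay.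

Compound 3 carries a different core, and the difference between the two cores is not broken down here. Its inhibition constant sits close to those of compound 1 and compound 2, all three within the scatter of one another.

Compound 4, `CCc1nc(-c2ccc(Cl)cc2Cl)c(OC)nc1NC(CC)CC`, is not yet measured. It differs from compound 3 in one place: ethyl in place of methoxy on an aromatic carbon. This is the same kind of change as that from compound 2 to compound 1, but not the same: there the position was ortho to a large group, meta to a (pentan-3-yl)amino group and para to an ethyl group, while here it is ortho to a (pentan-3-yl)amino group, meta to a 2,4-dichlorophenyl group and para to a methoxy group.

With only the earlier pair to go by, the step from compound 3 to compound 4 in this assay is expected to be small, a 1.2-fold higher number from compound 3 to compound 4 (0.08 log units; within the scatter), because the matching step gave a 1.2-fold higher number from compound 2 to compound 1 (0.07 log units; within the scatter). For compound 4 the inhibition constant in this assay is estimated at 10 nM, likely between 5 nM and 22 nM.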

Compound 4, inhibition constant: 8 nM
Compound 4: middle estimate off by 1.3-fold (0.10 log units), on the high side; measured number inside the range.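

In this assay, putting ethyl in place of methoxy at the carbon ortho to a (pentan-3-yl)amino group gives a 1.1-fold lower number from compound 3 to compound 4 (0.02 log units; within the scatter), so the two compounds cannot be told apart in this read-out. Set beside the earlier pair, the change gives no detectable difference between the two cores: the same change on two cores in this assay, a 1.2-fold higher number (0.07 log units; within the scatter) from compound 2 to compound 1 and a 1.1-fold lower number (0.02 log units; within the scatter) from compound 3 to compound 4, 1.2-fold (0.09 log units) apart, within the scatter of two such steps. Within the data shown here, this shows that, in the two pairs at hand, methoxy and ethyl can be exchanged on the shared ring carbon without a step beyond the scatter, but it rests on only two pairs, with neighbouring groups that differ, and it does not show that the same would hold on a further core or at another ring position, nor does it explain why the steps are so small.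

On these data alone, whether a longer chain such as propyl or butyl at this carbon would also leave the inhibition constant within the scatter remains open, as does the outcome with an amine or a hydroxyl group there. Also open, as far as these compounds go, is whether compound 3 and compound 4, alike in this assay, would stay alike in any read-out other than this binding measurement.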